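An Isopropoxy Replaces the Sulfur Group in Compound 1

The source may hold more compounds than are shown below. What is called first, only, known or untested is meant among the compounds shown, and "the series" means these compounds.

Compound 1 `C[S+]([O-])c1ccc(CNC(=O)c2ccc(C(C)(C)C)cc2)cc1` gives the highest number of the three measured compounds in an assay on HeLa cells with Bile acid receptor (Homo sapiens) as the target, read by a luciferase reporter, with a stated time of 24 h (on this read-out higher numbers stand for an effect only at larger amounts of compound and lower numbers for an effect already at smaller amounts), namely 1300 nM. Compound 2 `CC(C)(C)c1ccc(C(=O)NCc2ccc(OCC(=O)O)cc2)cc1` gives 730 nM, which is a 1.8-fold lower number from compound 1 to compound 2 (0.25 log units; within the scatter). Compound 3 `CC(C)(C)c1ccc(C(=O)NCc2ccc(-c3nnn[nH]3)cc2)cc1` gives 120 nM, which is an 11-fold lower number from compound 1 to compound 3 (1.03 log units; beyond the scatter). Compound 4 `CC(C)Oc1ccc(CNC(=O)c2ccc(C(C)(C)C)cc2)cc1` differs from compound 1 by a group of 4 heavy atoms (3 carbon, 1 oxygen; no ring) in place of a group of 3 heavy atoms (1 carbon, 1 oxygen, 1 sulfur; no ring), on an aromatic carbon. Both measured steps from compound 1 replace the same group at the same place, but neither brings in isopropoxy: one step stayed within the scatter, the other was large. Going by the values given here, with no measured step involving isopropoxy, no clear direction can be read off. The estimate for compound 4 is a step of a 1.2-fold higher number from compound 1 to compound 4 (0.06 log units; within the scatter), expected to stay within the scatter. Compound 4 is expected to give 1500 nM, with a range from 500 nM to 4500 nM.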

Compound 4, half-maximal effective concentration: 170 nM
For compound 4 the middle estimate is 8.8-fold (0.95 log units) above the measured one; measured number outside the range, below it.
By their numbers in this assay, from the lowest: compounds 3 and 4 (each within the scatter of the next); then compounds 2 and 1 (each within the scatter of the next).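

The step of a 7.6-fold lower number from compound 1 to compound 4 (0.88 log units; beyond the scatter) shows that a group with no ring can also lower the number at this place on the aromatic ring, which earlier only the ring-bearing 1H-tetrazol-5-yl had done beyond the scatter. The step of a 1.4-fold higher number from compound 3 to compound 4 (0.15 log units; within the scatter) means that isopropoxy and 1H-tetrazol-5-yl cannot be told apart here. With the oxygen kept, the step of a 4.3-fold lower number from compound 2 to compound 4 (0.63 log units; beyond the scatter) shows that the group on that oxygen matters.

Whether a methoxy group or an amine here would give an equally low number stays open, and no measurement given here explains these differences.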